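Shortening the Amide Side Chain in a Small Series

This account rests on a few compounds, and the source may have more. Where it says the series, first, only, none or still open, it means among the compounds named here.

compound 1 `CCC(C)NC(=O)/C=C/c1c(/C=C/c2ccc(OC)cc2)cc(OC)cc1OC`: 3430 nM
compound 2 `COc1ccc(/C=C/c2cc(OC)cc(OC)c2/C=C/C(=O)N2CCCCC2)cc1`: 6050 nM
compound 3 `C#CCNC(=O)/C=C/c1c(/C=C/c2ccc(OC)cc2)cc(OC)cc1OC`: 4560 nM

Three compounds share one core and differ only in the group attached to the amide. In a functional assay on MCF7 cells (Homo sapiens) for inhibition, read by MTT assay, with a stated time of 48 h (a lower number here means a stronger inhibitor, a higher number a weaker inhibitor), compound 1 gives 3430 nM, and its companions lie close: a 1.8-fold higher number from compound 1 to compound 2 (0.25 log units; within the scatter) and a 1.3-fold higher number from compound 1 to compound 3 (0.12 log units; within the scatter) both stay within the scatter, so none of the three can be called the stronger inhibitor. Compound 4 `CCNC(=O)/C=C/c1c(/C=C/c2ccc(OC)cc2)cc(OC)cc1OC` is reached from compound 1 by hydrogen in place of ethyl on a saturated chain carbon bound to an amide-type nitrogen and a saturated chain carbon. The two measured steps at this amide position, piperidin-1-yl in place of (sec-butyl)amino and propargyl in place of sec-butyl, left the number essentially unchanged, and trimming sec-butyl to ethyl is a milder change again. The expectation is therefore no movement beyond the scatter: a 1.2-fold higher number from compound 1 to compound 4 (0.07 log units; within the scatter). Compound 4 is estimated at 4000 nM, with a likely range from 2000 nM to 8000 nM.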

Compound 4, half-maximal inhibitory concentration: 7060 nM
For compound 4 the middle estimate is 1.8-fold (0.25 log units) below the measured one; low and high end bracket the measured number.
By their numbers in this assay, from the lowest: compounds 1, 3, 2 and 4 (each within the scatter of the next, the first and the last beyond it).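

In this assay, among these compounds, trimming sec-butyl to ethyl is the first change at this amide position to go beyond the scatter, with a 2.1-fold higher number from compound 1 to compound 4 (0.31 log units; beyond the scatter), so even this small edit can register. The effect is modest and appears only against compound 1, as a 1.5-fold higher number from compound 3 to compound 4 (0.19 log units; within the scatter) and a 1.2-fold higher number from compound 2 to compound 4 (0.07 log units; within the scatter) both stay within the scatter. Nothing shown here offers a cause for this step.

Still open, going by these compounds, is whether methyl, or a longer chain such as hexyl, in place of ethyl would move the number further or bring it back toward that of compound 1.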